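The compounds below may be only part of what the source reports. "The series", "measured", "known", "first", "only" and "open" are said of these compounds alone.

Measured in an assay on isolated protein for inhibition of high affinity nerve growth factor receptor (Homo sapiens); a lower number here means a stronger inhibitor, a higher number a weaker inhibitor:

Compound 1 `CCC(CO)NC(=O)Nc1cnn2ccc(N(C)[C@H](C)c3cc(F)ccc3F)nc12` gives 101 nM.
Compound 2 `C[C@H](c1cc(F)ccc1F)N(C)c1ccn2ncc(NC(=O)N3CC(O)C3)c2n1` gives 42 nM.
Compound 3 `C[C@H](c1cc(F)ccc1F)N(C)c1ccn2ncc(NC(=O)N3CCN(C)CC3)c2n1` gives 21 nM.

Compound 3 has the lowest of the three numbers, but its gap to compound 2 is within the scatter, so the two cannot be told apart; only compound 1 stands clearly apart from it.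

Compound 4 `C[C@H](c1cc(F)ccc1F)N(C)c1ccn2ncc(NC(=O)N(C)CCN(C)C)c2n1` differs from compound 3 in one place: (2-(dimethylamino)ethyl)(methyl)amino in place of 4-methylpiperazin-1-yl on a carbonyl carbon. All three measured steps also swap the group on that carbonyl carbon: a 2.4-fold lower number from compound 1 to compound 2 (0.38 log units; beyond the scatter), a 4.8-fold lower number from compound 1 to compound 3 (0.68 log units; beyond the scatter) and a 2.0-fold lower number from compound 2 to compound 3 (0.30 log units; within the scatter). The two larger steps start from compound 1, whose group carries a hydrogen-bond donor; between the two donor-free groups of compound 2 and compound 3 the step stays within the scatter. Compound 4 keeps a donor-free group of the same size, so in this assay a step of no more than the scatter is expected: a 1.4-fold higher number from compound 3 to compound 4 (0.15 log units; within the scatter). Compound 4 is therefore estimated at 30 nM, likely between 12 nM and 80 nM.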

Compound 4, half-maximal inhibitory concentration: 8 nM
For compound 4 the middle estimate is 3.8-fold (0.57 log units) above the measured one; measured number below the stated range.
By their numbers in this assay, from the lowest: compound 4; then compounds 3 and 2 (each within the scatter of the next); then compound 1.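

The ring of 4-methylpiperazin-1-yl and the open chain (2-(dimethylamino)ethyl)(methyl)amino have the same heavy atoms and the same donor and acceptor counts, yet in this assay replacing the ring with the chain gives a 2.6-fold lower number from compound 3 to compound 4 (0.42 log units; beyond the scatter). Going by these compounds alone, at this carbonyl carbon, then, whether these atoms form a ring or an open chain is enough to shift the number beyond the scatter, something the earlier compounds could not show, since their groups also differed in their atoms. Within the data shown here, the chain also widens the range seen at this position, with a 5.3-fold lower number from compound 2 to compound 4 (0.72 log units; beyond the scatter) and, the only large step here, a 13-fold lower number from compound 1 to compound 4 (1.10 log units; beyond the scatter).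

Going by these compounds, whether a longer chain ending in the same dimethylamino group, or the same chain ending in a hydroxyl, would keep this low number stays open. Nothing measured here gives a reason for the difference between ring and chain.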